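A few compounds are considered here, and "the series" means these few. Any claim that something is new, unique, unknown or untested is made for them only; others in the source may bear on it.

Measured so far in a toxicity assay on L02 cells (Homo sapiens) for cytotoxicity, read by MTT assay, with a stated time of 72 h (on this read-out higher numbers stand for weaker inhibition and lower numbers for stronger inhibition), are two compounds
- Compound 1 `CC1(C)O[C@@H](CO)[C@H](Cn2cc(Cn3c4c(c5ccccc53)C(=O)c3c[n+]([O-])c5ccccc5c3C4=O)nn2)O1` gives 500 nM
- Compound 2 `O=C1c2c[n+]([O-])c3ccccc3c2C(=O)c2c1c1ccccc1n2CCCCN1CCCCC1` gives 610 nM

Compound 2 stands within the usual scatter of compound 1 on this read-out, so these two numbers cannot be ranked. The next compound to be tested is compound 3 `O=C1c2c[n+]([O-])c3ccccc3c2C(=O)c2c1c1ccccc1n2Cc1cn(C[C@@H](O)CO)nn1`. It keeps the shared core of compound 2 and changes the side chain: 1-(2,3-dihydroxypropyl)-1H-1,2,3-triazol-4-yl in place of 3-(piperidin-1-yl)propyl on a saturated chain carbon bound to an aromatic nitrogen. In words, 1-(2,3-dihydroxypropyl)-1H-1,2,3-triazol-4-yl takes the place of 3-(piperidin-1-yl)propyl on a saturated chain carbon bound to an aromatic nitrogen. Within the data shown here, this is a large swap, and no measured pair shows what such a swap does in this assay. Among the measured compounds shown here, the only guide is that compound 1 at 500 nM and compound 2 at 610 nM lie close together, so a large move is not expected. The expected result is a 1.3-fold higher number from compound 2 to compound 3 (0.12 log units; within the scatter), a small shift toward weaker inhibition that may well stay inside the scatter. Compound 3 is estimated at 800 nM, with an expected range from 250 nM to 2500 nM for the measurement.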

Compound 3, half-maximal inhibitory concentration: 490 nM
Beside the measured number, compound 3's estimate is 1.6-fold (0.21 log units) above it; the measured number falls inside the stated range.
By their numbers in this assay, from the lowest: compounds 3, 1 and 2 (each within the scatter of the next).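

In this assay, the large swap on a saturated chain carbon bound to an aromatic nitrogen gives a 1.2-fold lower number from compound 2 to compound 3 (0.10 log units; within the scatter) even though the two side chains share little: 3-(piperidin-1-yl)propyl has a six-membered non-aromatic ring and 0 hydrogen-bond donors, while 1-(2,3-dihydroxypropyl)-1H-1,2,3-triazol-4-yl has a five-membered aromatic ring and 2 hydrogen-bond donors. The other step, with 1,2-dihydroxyethyl in place of 5-(hydroxymethyl)-2,2-dimethyl-1,3-dioxolan-4-yl at the same kind of carbon, gives a 1.0-fold lower number from compound 1 to compound 3 (0.01 log units; within the scatter) and so shows that the three compounds cannot be told apart on this read-out, whether the side chain carries a free diol or a ring-closed one. Nothing available here explains why these different side chains read alike.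

The compounds shown leave open what a side chain ending in a carboxylic acid or a primary amine would do at this position, and whether a longer chain between the shared core and the triazole would change the number. They also leave open what the other stereocentre form of the 2,3-dihydroxypropyl group would give.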